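The source may hold more compounds than are shown below. What is called first, only, known or untested is meant among the compounds shown, and "the series" means these compounds.

Compound 3 `CC(C)N(N)c1nnc(-c2ccccc2Cl)s1` is one of three measured compounds built on a shared core. In a functional assay on the whole organism with Mus musculus as the target, with a stated time of 1 h (on this read-out higher numbers stand for an effect only at larger amounts of compound and lower numbers for an effect already at smaller amounts), compound 1 `Cc1ccccc1-c1nnc(N(N)C(C)C)s1` gives 49 mg/kg, and compound 2 `Cc1ccccc1-c1nnc(N(N)Cc2ccccc2)s1` gives 44 mg/kg. For compound 3 this assay reports only a limit, > 100 mg/kg, and no number beyond it (the limit of > 100 mg/kg in this assay, at which 1 of the 3 values shown sits). The comparison an at least 2.0-fold higher number from compound 1 to compound 3 (0.30 log units; that floor lies within the scatter) therefore rests on that limit, and where compound 3 truly stands is not known beyond the fact that it lies at the edge of what this assay reports.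

Compound 4 `NN(Cc1ccccc1)c1nnc(-c2ccccc2Cl)s1` differs from compound 3 by benzyl in place of isopropyl on a nitrogen on an aromatic ring. Within the data shown here, one measured step bears on this exchange: a 1.1-fold lower number from compound 1 to compound 2 (0.05 log units; within the scatter), where the same replacement on the same nitrogen gave a result within the scatter. Among the measured compounds shown here, nothing among the measured compounds points to this exchange moving the read-out in either direction, so the step that the limit leaves unreadable from compound 3 to compound 4 is expected to be small. Because compound 3 is known only through the limit > 100 mg/kg, compound 4 is expected most likely to be reported at a limit as well. The estimated value for compound 4 is 150 mg/kg, with a range from 60 mg/kg to 400 mg/kg.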

Compound 4, dose for half-maximal effect: 143 mg/kg
Estimate against measurement, compound 4: 1.0-fold (0.02 log units) above, within the range that was stated.
By their numbers in this assay, from the lowest: compounds 2 and 1 (each within the scatter of the next); then compound 4.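

With benzyl on the nitrogen, chloro in place of methyl on an aromatic carbon now has a step that can be read in full in this assay, and it is a 3.3-fold higher number from compound 2 to compound 4 (0.51 log units; beyond the scatter). The earlier compounds gave this change only as a floor, whereas it now has a measured size, and the two cases point the same way: the same change on two cores in this assay, an at least 2.0-fold higher number (0.30 log units; that floor lies within the scatter) from compound 1 to compound 3 and a 3.3-fold higher number (0.51 log units; beyond the scatter) from compound 2 to compound 4; the limit leaves it open whether they differ The step from compound 3 to compound 4, benzyl in place of isopropyl with chloro on the aromatic carbon, cannot be read, since compound 3 is known only through a limit: the limit of > 100 mg/kg in this assay, at which 1 of the 4 values shown sits.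

As far as these compounds go, it therefore stays open whether the change from methyl to chloro has the same size with isopropyl as with benzyl on the nitrogen, or whether the exchange of isopropyl for benzyl is as small with chloro as it is with methyl. Also open, from the compounds shown here alone, is how this read-out would respond to other groups on the same aromatic carbon, such as fluoro or methoxy, or to a longer chain in place of benzyl on the nitrogen.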